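Swapping the ring on an amide side chain

The compounds below may be only part of what the source reports. "The series", "measured", "known", "first", "only" and "open" are said of these compounds alone.

Measured so far in a physicochemical assay for solubility, read by spectrophotometry, measured as kinetic solubility, at pH 8, tested at 500 uM (on this read-out lower numbers stand for lower solubility and higher numbers for higher solubility), are three compounds.
- compound 1 `CNC(=O)c1ccncc1Nc1cc(-c2ccc3ccn(C)c3c2)c2nccnc2c1` gives 4 ug/mL
- compound 2 `CN(C)C(=O)c1ccncc1Nc1cc(-c2ccc3ccn(C)c3c2)c2nccnc2c1` gives 175 ug/mL
- compound 3 `Cn1ccc2ccc(-c3cc(Nc4cnccc4C(=O)NCC4COCCN4)cc4nccnc34)cc21` gives 239 ug/mL

Compound 3 sits in the upper pair of these numbers. Its gap to the nearest neighbour stays within the scatter (a 1.4-fold higher number from compound 2 to compound 3 (0.14 log units; within the scatter)), while its gap to the furthest is large (a 60-fold higher number from compound 1 to compound 3 (1.78 log units; beyond the scatter)).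

Compound 4 `CC(=O)N1CC(CNC(=O)c2ccncc2Nc2cc(-c3ccc4ccn(C)c4c3)c3nccnc3c2)C1` is still unmeasured. It carries 1-acetylazetidin-3-yl in place of morpholin-3-yl on a saturated chain carbon bound to an amide-type nitrogen.

For the measured compounds named here, no measured step makes this exact swap, so the evidence is indirect. Compound 1 shows that small changes around the amide-type nitrogen can matter greatly (a 44-fold higher number from compound 1 to compound 2 (1.64 log units; beyond the scatter)). Yet two quite different changes there ended level, so part of the large gain may well survive the swap, and some may be lost.

The expected step in this assay is small and downward (a 1.8-fold lower number from compound 3 to compound 4 (0.26 log units; within the scatter)). The estimated value for compound 4 is 130 ug/mL (expected range 35 ug/mL to 250 ug/mL).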

Compound 4, solubility: 252 ug/mL
Compound 4: middle estimate off by 1.9-fold (0.29 log units), on the low side; the measured number lies above the stated range.
By their numbers in this assay, from the lowest: compound 1; then compounds 2, 3 and 4 (each within the scatter of the next).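

In this assay, 1-acetylazetidin-3-yl and morpholin-3-yl read level (a 1.1-fold higher number from compound 3 to compound 4 (0.02 log units; within the scatter)), even though the entering group has a four-membered rather than a six-membered ring, no hydrogen-bond donor where the leaving group has one, and a double bond outside aromatic rings. The comparison with dimethylamino on the carbonyl carbon also stays level (a 1.4-fold higher number from compound 2 to compound 4 (0.16 log units; within the scatter)), while the large gap to the smaller side chain remains (a 63-fold higher number from compound 1 to compound 4 (1.80 log units; beyond the scatter)). Among these compounds, then, the high number at this position does not depend on the morpholin-3-yl ring or its hydrogen-bond donor, and only compound 1 sits apart.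

Nothing measured here explains why these different side chains end level. From the compounds shown here alone, whether a side chain ending in a carboxylic acid, or a longer chain carrying a simple amine, would read level too remains open.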